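Aryl urea series: second chloro on the aromatic ring

A few compounds are considered here, and "the series" means these few. Any claim that something is new, unique, unknown or untested is made for them only; others in the source may bear on it.

In an ADME assay on the whole organism with Oryza sativa as the target, tested at 1 uM (on this read-out lower numbers stand for a stronger effect and higher numbers for a weaker effect at the one concentration tested), the measured compounds stand thus:
compound 1 `CCOC(=O)c1cccc(NC(=O)N[C@@H](C)c2ccccc2)c1` gives 99%
compound 2 `C[C@H](NC(=O)Nc1cccc(Cl)c1)c1ccccc1` gives 99%

Compound 2 is level with compound 1 at the digits shown, the one measured step being no change at the digits printed from compound 1 to compound 2 (within the scatter). Compound 3 `C[C@H](NC(=O)Nc1ccc(Cl)c(Cl)c1)c1ccccc1` carries chloro in place of hydrogen on an aromatic carbon. For the measured compounds named here, that single step is the only guide to this change, and it showed no movement in this assay. With nothing else to go on, compound 3 is expected to give no step beyond the scatter, a number 2 percentage points lower from compound 2 to compound 3 (within the scatter). Compound 3 is therefore estimated at 97%, with a range from 85% to 100%.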

Compound 3, a percentage reported as activity, at one concentration (the size of the read-out at that concentration, not a potency): 97%
Compound 3: middle estimate and measured number agree at the digits printed, and the stated range covers the measured number.
By their numbers in this assay, from the lowest: compounds 3, 1 and 2 (each within the scatter of the next).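

In this assay, chloro in place of hydrogen, ortho to a chloro group and para to a large group, gives a number 2 percentage points lower from compound 2 to compound 3 (within the scatter). This position therefore takes a second chloro with no step beyond the scatter, whereas the earlier step covered only chloro in place of ethoxycarbonyl. No measurement here bears on the reason for this flat result.

Open, on these data alone, is whether an amine, a methoxy group or a carboxylic acid at this position would give a step beyond the scatter. Also open, as far as these compounds go, is whether a longer chain in place of the methyl group on the shared core would do so.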